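Methyl in Place of Methoxy: Expected Exposure for Compound 4

The source may report more compounds than this note shows. Statements on the series, on what has been measured and on what is new or still open speak of the compounds shown alone.

In an ADME assay, in phosphate buffer, with a stated time of 30 min, tested at 1 mM, at a dose of 1 mM (on this read-out higher numbers stand for higher exposure at the dose given and lower numbers for lower exposure), compound 1 `COc1ccc(-n2sc(=O)n(-c3ccccc3)c2=O)cc1` gives < 2000 nM, which is a limit of the assay rather than a number. Compound 2 `COc1ccc(-n2sc(=O)n(C3CCCCC3)c2=O)cc1`, with cyclohexyl in place of phenyl on an aromatic nitrogen, gives < 2000 nM in this assay, again a limit. The step that the two limits leave unreadable from compound 1 to compound 2 cannot be read. Going by the values given here, compound 3 `COc1ccc(-n2sc(=O)n(Cc3ccccc3)c2=O)cc1`, carrying benzyl on that nitrogen, is the only member of the set with a measured number, 5490 nM in this assay; the steps of an at least 2.7-fold higher number from compound 1 to compound 3 (0.43 log units; beyond the scatter) and an at least 2.7-fold higher number from compound 2 to compound 3 (0.43 log units; beyond the scatter) both point upward. Compound 1 thus stands at the bottom of the measured range, at the limit of < 2000 nM in this assay, at which 2 of the 3 values shown sit.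

Compound 4 `Cc1ccc(-n2sc(=O)n(-c3ccccc3)c2=O)cc1` differs from compound 1 in a different place: methyl in place of methoxy on an aromatic carbon. The substituent on the aromatic nitrogen, phenyl, is kept. None of the three measured steps changes this part of the structure, so none bears on the change from compound 1 to compound 4, and no direction can be read from them. Compound 4 is expected to stay near where compound 1 sits, a step that the limit leaves unreadable from compound 1 to compound 4, and will most likely again be reported only as a limit. The estimate for compound 4 in this assay is 1500 nM, with a range from 500 nM to 4500 nM.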

Compound 4, maximal plasma concentration: < 2000 nM
Compound 4 gave a limit, no number; the forecaster's own chance of this, stated with the estimate: 60%; the middle value does not contradict the limit.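

Going by these compounds alone, compound 1 and compound 4 are both reported only as limits, so no step between them can be read in this assay and the lower end of the set stays as it was: the limit of < 2000 nM in this assay, at which 3 of the 4 values shown sit.

On these data alone, how far methyl in place of methoxy moves the read-out, and in which direction, remains open, including whether the change would act the same way with the benzyl of compound 3 on the aromatic nitrogen.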